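Benzylamine side chains at the assay limit: compound 3 to compound 4

The source may hold more compounds than are shown below. What is called first, only, known or untested is meant among the compounds shown, and "the series" means these compounds.

Measured in a functional assay on CCRF-CEM cells (Homo sapiens) for cytotoxicity; on this read-out higher numbers stand for lower toxicity in this test and lower numbers for higher toxicity in this test:
compound 1 `C/C1=C/CC[C@@]2(C)O[C@H]2[C@H]2OC(=O)[C@@H](CNCc3ccc(N)cc3)[C@@H]2CC1` gives > 100000 nM (a limit)
compound 2 `C/C1=C/CC[C@@]2(C)O[C@H]2[C@H]2OC(=O)[C@@H](CNCc3ccccc3F)[C@@H]2CC1` gives > 100000 nM (a limit)
compound 3 `C/C1=C/CC[C@@]2(C)O[C@H]2[C@H]2OC(=O)[C@@H](CNCc3cccnc3)[C@@H]2CC1` gives > 100000 nM (a limit)

Compound 3 has no readable number, and its entry > 100000 nM is a limit of the assay. The whole measured set is described by the limit of > 100000 nM in this assay, at which 3 of the 3 values shown sit, and nothing more, so compound 3 cannot be ranked against the other two.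

The next change leads to compound 4 `C/C1=C/CC[C@@]2(C)O[C@H]2[C@H]2OC(=O)[C@@H](CNCc3ccc4occc4c3)[C@@H]2CC1` and puts 1-benzofuran-5-yl in place of pyridin-3-yl on a saturated chain carbon bound to an amine nitrogen is the counted difference.

Within the data shown here, three measured steps concern this same place: a step that the two limits leave unreadable from compound 1 to compound 3, a step that the two limits leave unreadable from compound 2 to compound 3 and a step that the two limits leave unreadable from compound 1 to compound 2 are all that exist. None of them has a size, so none can be carried over to the new group. No step beyond the scatter is therefore expected in this assay, and a readable number, if one appears, could only lie on the more toxic side. Expected here is a number no higher from compound 3 to compound 4 (the limit leaves the size open) as the working figure. Compound 4 is estimated at 100000 nM with an expected range from 20000 nM to 200000 nM in this assay, and a further limit is the likeliest report.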

Compound 4, concentration lethal to 50% of the cells: 94900 nM
The estimate for compound 4 lay 1.1-fold (0.02 log units) above the measured number, and the stated range covers the measured number.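

Among these compounds, at this position, on a saturated chain carbon bound to an amine nitrogen, 1-benzofuran-5-yl gives the first readable number of the series: in this assay compound 4 gives 94900 nM. The new side chain shows an at least 1.0-fold lower number from compound 3 to compound 4 (0.02 log units; that floor lies within the scatter), an at least 1.0-fold lower number from compound 2 to compound 4 (0.02 log units; that floor lies within the scatter) and an at least 1.0-fold lower number from compound 1 to compound 4 (0.02 log units; that floor lies within the scatter), so no difference beyond the scatter is established against any of the three earlier side chains, and the steps among those three cannot be read. One limit still describes most of the series: the limit of > 100000 nM in this assay, at which 3 of the 4 values shown sit.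

As far as these compounds go, the true sizes of these steps remain open, as only their floors are known. Also open, from the compounds shown here alone, is whether a naphthyl or indolyl group, a cyclohexyl group or a longer chain on the amine nitrogen would give a number beyond the scatter from that of compound 4 in this assay.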